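Swapping the aryl group on the ring nitrogen

The compounds below may be only part of what the source reports. "The series", "measured", "known", "first", "only" and "open" are said of these compounds alone.

Measured compounds:
- compound 1 `Cc1ccc(-n2nncc2CN2C(=O)C3(C(C#N)=C(N)Oc4c3c3nc5ccccc5nc3c3ccccc43)c3ccccc32)cc1C`: > 50000 nM in a functional assay on A549 cells (Homo sapiens) for antiproliferative activity, read by MTT assay, with a stated time of 48 h; on this read-out higher numbers stand for weaker inhibition and lower numbers for stronger inhibition
- compound 2 `N#CC1=C(N)Oc2c(N)cc3nc4ccccc4nc3c2C12C(=O)N(Cc1cnnn1-c1cccc(Br)c1)c1ccccc12`: 18900 nM

Compound 1 reaches only the limit of this assay, (the limit of > 50000 nM in this assay, at which 1 of the 2 values shown sits), so no number is known for it. Within the data shown here, compound 2 is the only compound with a measured number, 18900 nM, which places it as a weak inhibitor of A549 cell growth. Its core differs from that of compound 1, so the two values cannot be compared as a single step.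

Compound 3 `Cc1ccc(C)c(-n2nncc2CN2C(=O)C3(C(C#N)=C(N)Oc4c(N)cc5nc6ccccc6nc5c43)c3ccccc32)c1` keeps the core of compound 2 and changes one group: 2,5-dimethylphenyl in place of 3-bromophenyl on an aromatic nitrogen. Among the measured compounds shown here, both groups are plain aromatic rings without hydrogen-bond donors or acceptors, and no measured step with this kind of change is available here. The change is therefore expected to move the value of compound 3 little, within the usual scatter or only slightly beyond it, and the expected step is a 1.3-fold higher number from compound 2 to compound 3 (0.12 log units; within the scatter). Compound 3 is estimated at 25000 nM, with a range from 8000 nM to 60000 nM, and there is a real chance that this assay reports only a limit for it.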

Compound 3, half-maximal inhibitory concentration: > 50000 nM
Compound 3: no number, only a limit (the forecaster's own chance of this, stated with the estimate: 30%); at least 2.0-fold (0.30 log units) between middle value and limit.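

Among these compounds, this is the first step that can be read on this core, and it falls on the aryl group carried by an aromatic nitrogen of the five-membered ring: 2,5-dimethylphenyl in place of 3-bromophenyl gives an at least 2.6-fold higher number from compound 2 to compound 3 (0.42 log units; beyond the scatter) in this assay. Compound 3 gives > 50000 nM, which is a limit of this assay and not a number, so the step has a known lower bound but no known size. This position therefore responds to the choice of aryl group, even though both groups are single carbon-only aromatic rings with no hydrogen-bond donors or acceptors, and little readable range remains at the weak end: the limit of > 50000 nM in this assay, at which 2 of the 3 values shown sit.

The step swaps the bromine for two methyl groups in one move, so these compounds cannot tell whether losing the bromine or adding the methyl groups matters more. From the compounds shown here alone, how the value would respond to a phenyl ring carrying an amine or a carboxylic acid at this position also remains open, as these compounds hold only plain aryl groups here.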